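This account rests on a few compounds, and the source may have more. Where it says the series, first, only, none or still open, it means among the compounds named here.

Notes on the series. For the measured compounds named here, compound 1 `CN(C)CCCCCSC1=Nc2ccccc2C(CC(=O)NCc2ccccc2)N1c1ccc(-c2ccc(F)cc2)cc1` and compound 2 `O=C(CC1c2ccccc2N=C(SCCCCCN2CCCC2)N1c1ccc(-c2ccc(F)cc2)cc1)NCc1ccc(F)cc1` share one core but differ in two places, so no single step connects them; only their two values stand side by side. In an assay on cells for inhibition of Voltage-dependent T-type calcium channel subunit alpha-1G (Homo sapiens), read by patch clamp, tested at 10 uM (a lower number here means less inhibition, a higher number more inhibition at the concentration tested (going by the name of the read-out)), compound 1 gives 97.6%. In this assay compound 2 gives 83.9%, the lowest of the two numbers, with compound 1 lying beyond the scatter on the higher side. Compound 3 `O=C(CC1c2ccccc2N=C(SCCCCCN2CCCC2)N1c1ccc(-c2ccc(F)cc2)cc1)NCc1ccccc1` is not yet measured in this assay. It is derived from compound 2 by a single change: hydrogen in place of fluoro on an aromatic carbon. Compound 3 therefore shares the rest of its structure with compound 2 and the benzylamino group with compound 1. Compound 1 reaches 97.6% in this assay carrying that benzylamino group, yet its amine end also differs from compound 2, so the weight of the fluoro alone cannot be read from the two values. For compound 3 the expected step in this assay is a number 6.1 percentage points higher from compound 2 to compound 3 (within the scatter), a modest rise that may not clear the scatter. The estimated value for compound 3 in this assay is 90%, with a range from 78% to 98%.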

Compound 3, a percentage reported as inhibition, at one concentration (the size of the read-out at that concentration, not a potency): 83.9%
Compound 3: middle estimate off by 6.1 percentage points, on the high side; the measured number falls inside the stated range.
By their numbers in this assay, from the lowest: compounds 2 and 3 (each within the scatter of the next); then compound 1.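

In this assay, hydrogen in place of fluoro on the aromatic carbon para to a large group gives no change at the digits printed from compound 2 to compound 3 (within the scatter), so with the pyrrolidin-1-yl end in place, 4-fluorobenzyl and benzyl read alike at this position. The amine end can now be read as a single change: pyrrolidin-1-yl in place of dimethylamino on a saturated chain carbon, five bonds along the chain from a sulfur, gives a number 13.7 percentage points lower from compound 1 to compound 3 (beyond the scatter), a modest step and the only one of the two that lies beyond the scatter. Nothing shown accounts for either result.

On these data alone, whether the fluoro is equally without effect alongside the dimethylamino end remains open, as does how a chloro or methoxy group would read at the same aromatic carbon. At the chain end, a piperidine, a morpholine or a primary amine could show whether the step belongs to the pyrrolidin-1-yl group in particular. The read-out comes from a single concentration. It gives no potency for any of these compounds.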